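Dropping the Oxazole Ester from a Ketone Inhibitor

The source may report more compounds than this note shows. Statements on the series, on what has been measured and on what is new or still open speak of the compounds shown alone.

Among the numbers shown for an assay for inhibition of Fatty-acid amide hydrolase 1 (Rattus norvegicus) (a higher number here means a weaker inhibitor, a lower number a stronger inhibitor), compound 2 `COC(=O)c1cnc(C(=O)CCc2ccc(COc3ccccc3)cc2)o1` stands lowest with 1.6 nM. Compound 3 `N#Cc1cccc(-c2cnc(C(=O)CCc3ccc(-c4ccccc4)cc3)o2)n1` gives 2.9 nM in this assay, which lies within the scatter of the value of compound 2, so no order between the two can be claimed. Compound 1 `NC(=O)c1ccc(-c2cnc(C(O)CCc3ccc(-c4ccccc4)cc3)o2)nc1` reaches only a limit in this assay, reported as > 1000 nM. That limit is the limit of > 1000 nM in this assay, at which 1 of the 3 values shown sits.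

Compound 4 `O=C(CCc1ccc(COc2ccccc2)cc1)c1ncco1` has not yet been measured. It differs from compound 2 in one place: hydrogen in place of methoxycarbonyl on an aromatic carbon, in words, hydrogen in place of methoxycarbonyl on an aromatic carbon. Among the compounds with values here, no pair of measured compounds covers this change, so the size of the step has to be estimated. The step of a 16-fold higher number from compound 2 to compound 4 (1.19 log units; beyond the scatter) is expected to run toward a higher number, beyond the scatter, since compound 2 sits at the low end of the values shown and a large group leaves the five-membered ring. Compound 4 is therefore estimated to give 25 nM in this assay, with a range from 5 nM to 120 nM.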

Compound 4, inhibition constant: 25 nM
Compound 4: the middle estimate sits on the measured number at the digits printed; measured number inside the range.
By their numbers in this assay, from the lowest: compounds 2 and 3 (each within the scatter of the next); then compound 4. At a limit, above all of these: compound 1.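

Taking the methoxycarbonyl off the aromatic carbon next to the ring oxygen gives, in this assay, a 16-fold higher number from compound 2 to compound 4 (1.19 log units; beyond the scatter), the first reading of this change, since all three earlier compounds carried a group on this carbon. The group therefore counts for a good part of the value of compound 2, yet it is not indispensable, as compound 4, with only hydrogen there, still gives 25 nM. Nothing measured here gives a cause for this step.

The compounds shown leave open whether a carboxylic acid, a primary amide or a methyl group on this carbon would keep the low number of compound 2 or follow compound 4. They also leave open whether the step would keep its size on the longer side chain of compound 3.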